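Hydroxyphenyl Gives Way to Fluorophenyl on a Saturated Ring Carbon

The source may hold more compounds than are shown below. What is called first, only, known or untested is meant among the compounds shown, and "the series" means these compounds.

Of the compounds shown here, two have so far been tested in a functional assay on HEK293 cells for agonist activity at D(4) dopamine receptor (Homo sapiens), read by FLIPR; on this read-out higher numbers stand for larger maximal responses and lower numbers for smaller maximal responses. Compound 1 `O=C(CN1CCC(c2cccc[n+]2[O-])CC1)Nc1cccc(Cl)c1` gives 76% in this assay. Compound 2 `Cc1cccc(NC(=O)CN2CCC(c3cccc(O)c3)CC2)c1` gives 66% in this assay, and so stands at the foot of the two numbers shown. This position carries little weight: its gap to compound 1 lies within the usual scatter of repeated measurements, so the two cannot be separated.

Compound 3 `Cc1cccc(NC(=O)CN2CCC(c3ccccc3F)CC2)c1` has not yet been measured. It differs from compound 2 in one place: 2-fluorophenyl in place of 3-hydroxyphenyl on a saturated ring carbon. Going by the values given here, compound 1 and compound 2 differ from each other in more than one place, so no measured pair shows what a single change of this kind does in this assay, and the expectation for compound 3 rests on the two numbers alone. For compound 3 the estimate amounts to a step of a number 1 percentage points lower from compound 2 to compound 3 (within the scatter), that is, no change beyond the scatter. Compound 3 is therefore expected to give 65% in this assay, with a range from 45% to 85%.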

Compound 3, largest response reached (reported as efficacy), in percent of the reference or control that the assay uses: 57%
For compound 3 the middle estimate is 8 percentage points above the measured one; the range from low to high includes it.
By their numbers in this assay, from the lowest: compounds 3, 2 and 1 (each within the scatter of the next, the first and the last beyond it).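

Going by these compounds alone, this is the first step between measured compounds that differ in one place, and in this assay it amounts to a number 9 percentage points lower from compound 2 to compound 3 (within the scatter) and so gives no separation between the two. The group that leaves carries 1 hydrogen-bond donor and 1 hydrogen-bond acceptor and the group that enters carries neither, so for this pair a response that cannot be told apart from that of compound 2 does not depend on keeping the hydroxyl group at this place on the saturated ring carbon. Nothing measured alongside these compounds explains the size of this step, so the reading stops at the numbers themselves.

The swap also alters two things at once, the kind of substituent on the phenyl ring and where it sits on that ring, and this pair cannot show whether either matters alone or whether the two effects offset each other. A phenyl group with no substituent, or a phenyl group bearing a methoxy group or an amine, would show how much of the response at this place needs any substituent at all.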